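Taking the methyl off the aromatic ring of compound 2

A few compounds are considered here, and "the series" means these few. Any claim that something is new, unique, unknown or untested is made for them only; others in the source may bear on it.

In a functional assay on MDA-MB-231 cells (Homo sapiens) for inhibition, read by MTT assay, with a stated time of 72 h (on this read-out higher numbers stand for weaker inhibition and lower numbers for stronger inhibition), compound 1 `CC1=NN(c2ccccc2)C(=O)[C@]12C(=O)C=CC[C@H]2c1cccc(C)c1` gives 10300 nM and compound 2 `CC1=NN(c2ccccc2)C(=O)[C@]12C(=O)C=CC[C@@H]2c1cccc(C)c1` gives 8000 nM. Compound 2 therefore stands level with compound 1 within the scatter. Within the data shown here, the only measured step between them is a 1.3-fold lower number from compound 1 to compound 2 (0.11 log units; within the scatter), and it comes with the fact that compounds 1 and 2 differ only in the configuration as drawn. Compound 3 `CC1=NN(c2ccccc2)C(=O)[C@]12C(=O)C=CC[C@@H]2c1ccccc1` keeps the shared core and the drawn configuration of compound 2, and the change lies in the aromatic substituent: hydrogen in place of methyl on an aromatic carbon. This is hydrogen in place of methyl on an aromatic carbon, turning 3-methylphenyl into phenyl. Among the measured compounds shown here, no measured step touches that methyl, so the stereochemical step bears on it only as a sign of how flat the numbers have been so far. In this assay no shift beyond the scatter is therefore expected, and the expected result is a 1.1-fold higher number from compound 2 to compound 3 (0.05 log units; within the scatter). Compound 3 is estimated at 9000 nM, with an expected range of 3500 nM to 23000 nM.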

Compound 3, half-maximal inhibitory concentration: 9080 nM
For compound 3 the middle estimate is 1.0-fold (0.00 log units) below the measured one; the range from low to high includes it.
By their numbers in this assay, from the lowest: compounds 2, 3 and 1 (each within the scatter of the next).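

In this assay hydrogen in place of methyl on an aromatic carbon, turning 3-methylphenyl into phenyl, leaves the number within the scatter (a 1.1-fold higher number from compound 2 to compound 3 (0.05 log units; within the scatter)). Among these compounds, this is the first measured step at this position, as the earlier pair spoke only to configuration at a saturated ring carbon, and it shows that in the drawn configuration of compound 2 the methyl can be removed without a shift beyond the scatter. The material given here offers no explanation for this flat step.

Going by these compounds, whether a different group at this aromatic carbon, such as an amine, a carboxylic acid or a longer chain, would move the number stays open. So does whether phenyl in the drawn configuration of compound 1 would give a number level with that of compound 3.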